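Trifluoromethoxy in place of bromo on the anilide ring

This account rests on a few compounds, and the source may have more. Where it says the series, first, only, none or still open, it means among the compounds named here.

Three salicylanilides sharing one core have been examined in a functional assay on KG-1 cells (Homo sapiens) for cytotoxicity, read by luminescence and CellTiter-Glo, with a stated time of 3 days; on this read-out higher numbers stand for weaker inhibition and lower numbers for stronger inhibition. Compound 1 `N#Cc1ccc(NC(=O)c2ccc(F)cc2O)cc1` gives 3150 nM in this assay. Compound 2 `O=C(Nc1ccc(OC(F)(F)F)cc1)c1cc(F)ccc1O` gives 780 nM in this assay. Compound 3 `O=C(Nc1ccc(Br)c(Cl)c1)c1cc(F)ccc1O` gives 670 nM in this assay, the lowest of the three numbers; the gap to compound 2 lies within the usual scatter, so no order between those two can be claimed, whereas the gap to compound 1 lies beyond it.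

The next compound to be measured is compound 4 `O=C(Nc1ccc(OC(F)(F)F)c(Cl)c1)c1cc(F)ccc1O`. It differs from compound 3 in one place: trifluoromethoxy in place of bromo on an aromatic carbon. The chloro group stays where it was.

Among the three measured compounds, compound 2 carries the same trifluoromethoxy group without the chloro group, and its value in this assay sits within the scatter of compound 3. On that basis the step of a 1.1-fold lower number from compound 3 to compound 4 (0.05 log units; within the scatter) is expected to be small, with no clear direction beyond the scatter. Compound 4 is therefore estimated at 600 nM in this assay, within a range from 250 nM to 1500 nM.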

Compound 4, half-maximal inhibitory concentration: 370 nM
The estimate for compound 4 lay 1.6-fold (0.21 log units) above the measured number, and the stated range covers the measured number.
By their numbers in this assay, from the lowest: compounds 4, 3 and 2 (each within the scatter of the next, the first and the last beyond it); then compound 1.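

In this assay the exchange of bromo for trifluoromethoxy, ortho to a chloro group and para to a large group, gives a 1.8-fold lower number from compound 3 to compound 4 (0.26 log units; within the scatter), so this position accepts either group, and the two cannot be placed in any order here. The chloro group carries the clearer signal: chloro in place of hydrogen on an aromatic carbon gives a 2.1-fold lower number from compound 2 to compound 4 (0.32 log units; beyond the scatter), a modest step and the only one of the two that lies beyond the scatter, which shows that the number can still move once trifluoromethoxy is in place. What lies behind the size of either step cannot be told from the information at hand.

On these data alone, it remains open whether an amine, a carboxylic acid or a longer alkoxy chain at the place held by trifluoromethoxy would keep a number in this range in this assay, and whether a methyl or a methoxy group in place of the chloro group would give a step of like size. The compounds shown also leave open how far the step for chloro carries over to partners other than trifluoromethoxy, such as the nitrile of compound 1, and what happens when the fluoro or hydroxy group on the other ring is replaced.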